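Furan-3-yl replacing 2,4-dimethoxyphenyl: cytotoxicity notes

The compounds below may be only part of what the source reports. "The series", "measured", "known", "first", "only" and "open" are said of these compounds alone.

Three measured compounds frame this step: compound 1 `C/C(=N\NC(N)=S)c1ccc2c(c1)nc(-c1ccc(Cl)cc1)n2C1CCCCC1`, compound 2 `COc1ccc(-c2nc3cc(/C(C)=N/NC(N)=S)ccc3n2C2CCCCC2)cc1` and compound 3 `COc1ccc(-c2nc3cc(/C(C)=N/NC(N)=S)ccc3n2C2CCCCC2)c(OC)c1`. In an ADME assay on MDBK cells (Bos taurus) for cytotoxicity, read by MTT assay, with a stated time of 96 h (on this read-out lower numbers stand for higher toxicity in this test and higher numbers for lower toxicity in this test), compound 1 gives > 100000 nM, which is a limit of the assay. Compound 2 gives 32000 nM, a measured number. Compound 3 gives > 100000 nM, which is also a limit and not a number. Compound 3 therefore stands at the limit of > 100000 nM in this assay, at which 2 of the 3 values shown sit.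

Compound 4 `C/C(=N\NC(N)=S)c1ccc2c(c1)nc(-c1ccoc1)n2C1CCCCC1` carries furan-3-yl in place of 2,4-dimethoxyphenyl on an aromatic carbon.

Among the measured compounds shown here, three measured steps concern the group at that place. The first is an at least 3.1-fold lower number from compound 1 to compound 2 (0.49 log units; beyond the scatter). The second is an at least 3.1-fold higher number from compound 2 to compound 3 (0.49 log units; beyond the scatter). The third is a step that the two limits leave unreadable from compound 1 to compound 3. The two readable steps run in opposite directions, and none has a five-membered aromatic ring entering. For the measured compounds named here, the expectation therefore rests mainly on compound 2, whose 32000 nM is the one actual number. In this assay a modest move toward a lower number is expected, though a result at the limit would remain unreadable. The expected change is an at least 1.3-fold lower number from compound 3 to compound 4 (0.12 log units; that floor lies within the scatter). Compound 4 is estimated at 75000 nM, with an expected range from 25000 nM to 150000 nM.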

Compound 4, half-maximal cytotoxic concentration: > 100000 nM
Compound 4 was reported as a limit; the forecaster's own chance of this, stated with the estimate: 45%; at least 1.3-fold (0.12 log units) between middle value and limit.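

In this assay compound 4 gives > 100000 nM, which is a limit of the assay and not a number. Furan-3-yl, with 5 heavy atoms and a five-membered aromatic ring, therefore ends at the same limit as the larger 4-chlorophenyl and 2,4-dimethoxyphenyl groups at this place, so a six-membered aromatic ring of carbon only is not needed to reach it, and the series now gathers here: the limit of > 100000 nM in this assay, at which 3 of the 4 values shown sit. The one readable step is an at least 3.1-fold higher number from compound 2 to compound 4 (0.49 log units; beyond the scatter), which leaves 4-methoxyphenyl as the only group shown at this place with a measured number, while the steps among the three compounds at the limit cannot be read.

On these data alone, how far these three compounds lie from one another remains unknown, and so does whether the measured number of compound 2 reflects something particular to 4-methoxyphenyl or would recur with other groups at this place. Thiophen-3-yl would test the ring hetero atom, while an aminomethyl or carboxylic acid group on the furan ring would show whether this place can carry an amine or an acid and still stay at the limit.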